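A Chlorophenyl-Ethenyl Extension on the Acetyl Arm

The source may report more compounds than this note shows. Statements on the series, on what has been measured and on what is new or still open speak of the compounds shown alone.

Of the compounds shown here, three that share one core have been tested in a functional assay on SMMC-7721 cells (Homo sapiens) for cytotoxicity, read by MTT assay, with a stated time of 72 h; a lower number here means a stronger inhibitor, a higher number a weaker inhibitor. Compound 1 `O=C(CSC(=S)N[C@H]1CCOC1=O)Nc1ccc(Br)cc1` gives 28300 nM in this assay. Compound 2 `Cc1ccc(NC(=O)CSC(=S)N[C@H]2CCOC2=O)cc1` gives 32700 nM in this assay. For compound 3 `CC(=O)c1ccc(NC(=O)CSC(=S)N[C@H]2CCOC2=O)cc1` this assay reports only a limit, > 128000 nM. The step of a 1.2-fold higher number from compound 1 to compound 2 (0.06 log units; within the scatter) lies within the scatter, whereas the steps of an at least 4.5-fold higher number from compound 1 to compound 3 (0.65 log units; beyond the scatter) and an at least 3.9-fold higher number from compound 2 to compound 3 (0.59 log units; beyond the scatter) lie beyond it; both of the latter rest on (the limit of > 128000 nM in this assay, at which 1 of the 3 values shown sits). Compound 3 therefore stands at the weak end of the three values shown, without a number of its own.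

Compound 4 `O=C(CSC(=S)N[C@H]1CCOC1=O)Nc1ccc(C(=O)/C=C/c2ccc(Cl)cc2)cc1` differs from compound 3 by 2-(4-chlorophenyl)ethenyl in place of methyl on a carbonyl carbon. Among the compounds with values here, none of the measured steps touches this part of the molecule: each of them exchanges a group on an aromatic carbon, and the carbonyl carbon is left as it is. The three steps shown thus give no direction and no size for the change from compound 3 to compound 4. The step of an at least 2.5-fold lower number from compound 3 to compound 4 (0.40 log units; beyond the scatter) is an expectation resting only on the limit of compound 3, and it is held loosely. Compound 4 is estimated at 50000 nM in this assay, with a range from 10000 nM to 250000 nM.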

Compound 4, half-maximal inhibitory concentration: > 128000 nM
Compound 4: only a limit was reported; the forecaster's own chance of this, stated with the estimate: 45%; middle value at least 2.5-fold (0.40 log units) away from the limit.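

In this assay, compound 3 and compound 4 are each reported only as a limit, so no step between them can be read: the limit of > 128000 nM in this assay, at which 2 of the 4 values shown sit.

The compounds shown leave open where the values of compound 3 and compound 4 actually lie, and whether 2-(4-chlorophenyl)ethenyl in place of methyl on a carbonyl carbon changes the read-out at all.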